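Replacing 4-hydroxy-3-nitrophenyl with 4-chlorophenyl on compound 1

A few compounds are considered here, and "the series" means these few. Any claim that something is new, unique, unknown or untested is made for them only; others in the source may bear on it.

Among the measured compounds shown here, in a functional assay on DU-145 cells (Homo sapiens) for inhibition, read by trypan blue exclusion, with a stated time of 96 h (on this read-out lower numbers stand for stronger inhibition of growth and higher numbers for weaker inhibition of growth), compound 1 `Cc1ccc(S(=O)(=O)/C(=C/c2ccc(O)c([N+](=O)[O-])c2)C(=O)c2ccc(Cl)cc2)cc1` gives 25000 nM, the highest number of the three measured so far and therefore the weakest inhibition of growth. Compound 2 `O=C(/C(=C\c1ccc(O)c([N+](=O)[O-])c1)SCc1ccc(Cl)cc1)c1ccc(Cl)cc1` gives 10000 nM. Compound 3 `O=C(/C(=C\c1ccc(O)c([N+](=O)[O-])c1)SCc1ccccc1Cl)c1ccc(Cl)cc1` gives 10000 nM. Both of these carry a chlorobenzyl sulfanyl group in place of the (4-methylphenyl)sulfonyl group, which gives a 2.5-fold lower number from compound 1 to compound 2 (0.40 log units; beyond the scatter) and a 2.5-fold lower number from compound 1 to compound 3 (0.40 log units; beyond the scatter). Exchanging 4-chlorophenyl for 2-chlorophenyl on that group gives no change at the digits printed from compound 2 to compound 3 (within the scatter).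

Compound 4 `Cc1ccc(S(=O)(=O)/C(=C/c2ccc(Cl)cc2)C(=O)c2ccc(Cl)cc2)cc1` keeps the (4-methylphenyl)sulfonyl group and changes something else: 4-chlorophenyl in place of 4-hydroxy-3-nitrophenyl on a double-bonded chain carbon bound to a double-bonded chain carbon. For the measured compounds named here, no measured step touches the 4-hydroxy-3-nitrophenyl group, so the direction of this change in this assay remains open. The steps above offer only a sense of scale, with compound 2 showing a 2.5-fold lower number from compound 1 to compound 2 (0.40 log units; beyond the scatter). The expected change is a 1.7-fold lower number from compound 1 to compound 4 (0.22 log units; within the scatter), a slight lean that the data cannot settle. Compound 4 is estimated at 15000 nM, with an expected range from 4000 nM to 50000 nM.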

Compound 4, concentration for 50% growth inhibition: 1000 nM
Compound 4: the middle estimate sits 15-fold (1.18 log units) above what was measured; the measured number lies below the stated range.
By their numbers in this assay, from the lowest: compound 4; then compounds 2 and 3 (each within the scatter of the next); then compound 1.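

In this assay, the group on a double-bonded chain carbon bound to a double-bonded chain carbon turns out to matter a great deal: 4-chlorophenyl in place of 4-hydroxy-3-nitrophenyl gives the stronger inhibition of growth (a 25-fold lower number from compound 1 to compound 4 (1.40 log units; beyond the scatter)). This step is larger than the one seen on changing the sulfur-bearing group (a 2.5-fold lower number from compound 1 to compound 2 (0.40 log units; beyond the scatter)), so among the steps shown, this place responds most. No measurement here explains the drop in the number.

As far as these compounds go, the hydroxyl and nitro groups leave together, so how a 4-hydroxyphenyl, a 3-nitrophenyl or a plain phenyl group would read at this place stays open. Also open, from the compounds shown here alone, is whether 4-chlorophenyl would give a similar step in compounds carrying the chlorobenzyl sulfanyl groups of compound 2 and compound 3.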